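The source may hold more compounds than are shown below. What is called first, only, known or untested is meant among the compounds shown, and "the series" means these compounds.

Compound 1 `Cc1cc(C(=O)NCN2CCC(c3cccc[n+]3[O-])CC2)ccc1F` is the starting point of this account. Going by the values given here, in a functional assay on HEK293 cells for agonist activity at D(4) dopamine receptor (Homo sapiens), read by FLIPR (on this read-out higher numbers stand for an effect only at larger amounts of compound and lower numbers for an effect already at smaller amounts), compound 1 gives 50 nM, the higher of the two numbers measured so far. Compound 2 `c1ccc(C2CCN(Cc3nc4ccccc4[nH]3)CC2)nc1` gives 12 nM in this assay, a lower number that lies beyond the usual scatter. Compound 3 `O=C(NCN1CCC(c2cccc[n+]2[O-])CC1)c1cc(Cl)cc(Cl)c1` differs from compound 1 in one place: 3,5-dichlorophenyl in place of 4-fluoro-3-methylphenyl on a carbonyl carbon. Among the compounds with values here, no measured pair shows this change, so its effect is not anchored by any observed step. A small step is expected, a 1.3-fold lower number from compound 1 to compound 3 (0.10 log units; within the scatter), not clearly beyond the scatter. Compound 3 is expected to give about 40 nM, most likely between 15 nM and 120 nM.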

Compound 3, half-maximal effective concentration: 45 nM
For compound 3 the middle estimate is 1.1-fold (0.05 log units) below the measured one, and the stated range covers the measured number.
By their numbers in this assay, from the lowest: compound 2; then compounds 3 and 1 (each within the scatter of the next).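

In this assay, going by these compounds alone, the exchange of 4-fluoro-3-methylphenyl for 3,5-dichlorophenyl on the carbonyl carbon gives a 1.1-fold lower number from compound 1 to compound 3 (0.05 log units; within the scatter), the first step that can be read at this place. The two compounds therefore stand level, so this place accepts both of these substituted phenyl groups, although this single pair is all that speaks to it. No measurement at hand accounts for this result. As far as these compounds go, what remains open is how an unsubstituted phenyl, or a cyclohexyl group without an aromatic ring, would read at the same place.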